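The source may hold more compounds than are shown below. What is called first, only, known or untested is meant among the compounds shown, and "the series" means these compounds.

Measured so far in a functional assay on the whole organism (strain albino) for inhibition, with Rattus norvegicus as the target, read by paw edema, with a stated time of 1 h, at a dose of 0.28 mmol/kg by the oral route; on this read-out higher numbers stand for more inhibition at the one dose given (going by the name of the read-out) and lower numbers for less inhibition:

Compound 1 `COc1ccc(-c2nnc(SC/C(=N/O)c3ccccc3)n2-c2ccccc2)cc1` gives 58%.
Compound 2 `C=CCn1c(SC/C(=N/O)c2ccccc2)nnc1-c1ccc(OC)cc1` gives 61%.
Compound 3 `C=CCn1c(SCC(=O)c2ccccc2)nnc1-c1ccc(OC)cc1` gives 49%.

On these numbers compound 2 holds the highest value of the three, but its lead over compound 1 is a step of a number 3 percentage points higher from compound 1 to compound 2 (within the scatter), which lies within the scatter, so the two cannot be ranked against each other. Only compound 3 sits clearly apart from compound 2, by a step of a number 12 percentage points lower from compound 2 to compound 3 (beyond the scatter), and that step concerns the chain bound to sulfur rather than the group on the aromatic nitrogen.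

The unmeasured compound 4 `CCn1c(SC/C(=N/O)c2ccccc2)nnc1-c1ccc(OC)cc1` differs from compound 2 in one place: methyl in place of vinyl on a saturated chain carbon bound to an aromatic nitrogen. Cut one bond further out, the same change reads allyl to ethyl.

Among the measured compounds shown here, the one measured step that touches the same position is the exchange of phenyl for allyl on the aromatic nitrogen, from compound 1 to compound 2, and it stayed within the scatter. A far larger group was exchanged there with no clear effect, so the smaller move from allyl to ethyl is expected to produce no step beyond the scatter in this assay, the estimated step being a number 3 percentage points lower from compound 2 to compound 4 (within the scatter).

Compound 4 is therefore expected to give about 58%, within a range from 46% to 70%.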

Compound 4, a percentage reported as inhibition, in the whole organism at one dose (the size of the read-out at that dose, not a potency): 69%
The estimate for compound 4 lay 11 percentage points below the measured number, and the stated range covers the measured number.
By their numbers in this assay, from the lowest: compounds 3, 1, 2 and 4 (each within the scatter of the next, the first and the last beyond it).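

In this assay the change from allyl to ethyl, read as methyl in place of vinyl on a saturated chain carbon bound to an aromatic nitrogen, gives a number 8 percentage points higher from compound 2 to compound 4 (within the scatter) and so leaves compound 2 and compound 4 unranked against each other. Among the compounds shown here, what the earlier compounds did not show is a step beyond the scatter at this position: ethyl in place of phenyl on the aromatic nitrogen gives a number 11 percentage points higher from compound 1 to compound 4 (beyond the scatter) and this modest step stands against a number 3 percentage points higher from compound 1 to compound 2 (within the scatter) for allyl in place of phenyl, so the group on this nitrogen is no longer without any readable effect. No measurement is at hand that would account for these steps.

The compounds shown leave open how methyl, a longer chain such as butyl, or benzyl on the aromatic nitrogen would read in this assay and whether any of them would stand clearly apart from ethyl. Also open, going by these compounds, is whether the step at the chain bound to sulfur, a number 12 percentage points lower from compound 2 to compound 3 (beyond the scatter) with allyl on the nitrogen, would recur with ethyl there.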